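A Thiophene-to-Furan Swap in a Growth Inhibition Series

The compounds below may be only part of what the source reports. "The series", "measured", "known", "first", "only" and "open" are said of these compounds alone.

Compound 1 `COc1cc(C(=O)NNC(=O)c2ccc3[nH]c(-c4ccc([N+](=O)[O-])s4)nc3c2)cc(OC)c1OC` gives 62.5 ug/mL
Compound 2 `COc1cccc(C(=O)NNC(=O)c2ccc3[nH]c(-c4ccc([N+](=O)[O-])o4)nc3c2)c1` gives 31.3 ug/mL
Compound 3 `O=C(NNC(=O)c1cc2ccccc2cc1O)c1ccc2[nH]c(-c3ccc([N+](=O)[O-])s3)nc2c1` gives 62.5 ug/mL

In a functional assay on HT-29 cells (Homo sapiens) for inhibition, read by sulforhodamine B assay, with a stated time of 48 h (a higher number here means a weaker inhibitor of growth, a lower number a stronger inhibitor of growth), compound 1 gives 62.5 ug/mL and so stands level with compound 3, while compound 2 gives 31.3 ug/mL and still lies within the usual scatter of compound 1. These three numbers therefore cannot be put in a firm order.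

Compound 4 `COc1cc(C(=O)NNC(=O)c2ccc3[nH]c(-c4ccc([N+](=O)[O-])o4)nc3c2)cc(OC)c1OC` is compound 1 with one change: 5-nitrofuran-2-yl in place of 5-nitrothiophen-2-yl on an aromatic carbon and the rest of the structure untouched. For the measured compounds named here, no pair of measured compounds shows this swap on its own, so the data give no direct size for it. The nearest hint is compound 2, which already carries the 5-nitrofuran-2-yl and gives 31.3 ug/mL but also differs from compound 4 elsewhere. The expectation in this assay is thus a small move toward a lower number, with nothing beyond the scatter, and the estimated step is a 1.6-fold lower number from compound 1 to compound 4 (0.19 log units; within the scatter) as a middle guess. Compound 4 is estimated at 40 ug/mL with an expected range from 15.6 ug/mL to 100 ug/mL in this measurement.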

Compound 4, concentration for 50% growth inhibition: 31.3 ug/mL
The estimate for compound 4 lay 1.3-fold (0.11 log units) above the measured number; measured number inside the range.
By their numbers in this assay, from the lowest: compounds 2, 4, 1 and 3 (each within the scatter of the next).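

In this assay, for the compounds shown here, putting 5-nitrofuran-2-yl in place of 5-nitrothiophen-2-yl gives a 2.0-fold lower number from compound 1 to compound 4 (0.30 log units; within the scatter) and so provides the first direct reading of this change on its own. On this aromatic carbon, with the rest of compound 1 untouched, exchanging one of these nitro-bearing rings for the other therefore leaves the read-out within the scatter. No independent measurement bears on this result.

As far as these compounds go, whether the same swap reads alike with the different group at the other end of compound 3 remains open. Also open, from the compounds shown here alone, is how this position would respond to a larger change, such as a plain phenyl ring in place of either five-membered ring, or an amine or a carboxylic acid in place of the nitro group.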